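Methoxy to trifluoromethoxy on compound 1

The compounds below may be only part of what the source reports. "The series", "measured", "known", "first", "only" and "open" are said of these compounds alone.

Values from a functional assay on L1210 cells (Mus musculus) for inhibition, read by cell counting, with a stated time of 48 h (on this read-out higher numbers stand for weaker inhibition and lower numbers for stronger inhibition), follow
- compound 1 (`COc1ccc(N(C)c2nc(C)nc3c2nc(C)n3C)cc1`) gives 19000 nM
- compound 2 (`COc1cccc(N(C)c2nc(C)nc3c2nc(C)n3C)c1`) gives > 250000 nM

Within the data shown here, compound 1, at 19000 nM in this assay, holds the only actual number so far, which makes it the single firm reference point. Compound 2 is reported as > 250000 nM and that entry is a limit of the assay, not a number.

The next compound to be tested is compound 3 (`Cc1nc(N(C)c2ccc(OC(F)(F)F)cc2)c2nc(C)n(C)c2n1`). It keeps the core of compound 1 and changes one group, methoxy to trifluoromethoxy: trifluoromethyl in place of methyl on an oxygen on an aromatic ring.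

Among the measured compounds shown here, no measured pair shows this swap, so the data offer no direct guide to its size. With compound 1 at 19000 nM as the only anchor, a small step in this assay is expected, perhaps within the usual scatter, with a slight lean toward weaker inhibition. The expected move is a 1.6-fold higher number from compound 1 to compound 3 (0.20 log units; within the scatter) and the uncertainty around it is wide. For compound 3 the estimate is 30000 nM in an expected range of 8000 nM to 120000 nM in this assay.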

Compound 3, half-maximal inhibitory concentration: > 250000 nM
Compound 3: only a limit was reported (the forecaster's own chance of this, stated with the estimate: 15%); at least 8.3-fold (0.92 log units) between middle value and limit.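

In this assay, trifluoromethyl in place of methyl on an oxygen on an aromatic ring turns out not to be a small exchange. It brings an at least 13-fold higher number from compound 1 to compound 3 (1.11 log units; beyond the scatter). The value of compound 3, > 250000 nM, is a limit of the assay and not a number, so this step has a lower bound but no measured size. Compound 1 therefore remains the only compound here with a firm number, while the others sit at one shared limit: the limit of > 250000 nM in this assay, at which 2 of the 3 values shown sit.

The compounds shown cannot tell which feature of the trifluoromethyl group lies behind this loss, or whether any other group on this oxygen would keep or improve on the inhibition seen with compound 1. An ethyl group or a longer chain on the oxygen, or an amine in place of the whole methoxy, would show whether the methoxy of compound 1 can be replaced at all, and would give numbers rather than another limit if inhibition stays within reach of this assay.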